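The source may report more compounds than this note shows. Statements on the series, on what has been measured and on what is new or still open speak of the compounds shown alone.

Compound 3 `O=C(Nc1ccc(N2CCN(c3ccc(OC[C@@H]4CO[C@@](Cn5cncn5)(c5ccc(Cl)cc5Cl)O4)cc3)CC2)cc1)c1ccc(F)c(F)c1` belongs to a small series built on one shared core, where the compounds differ only in the group attached to the amide carbonyl carbon. In a toxicity assay on L02 cells (Homo sapiens) for inhibition, read by MTT assay, with a stated time of 48 h (a higher number here means a weaker inhibitor, a lower number a stronger inhibitor), compound 3 gives > 50000 nM, which is a limit of the assay and not a number. Compound 1 `O=C(CCCCc1ccccc1)Nc1ccc(N2CCN(c3ccc(OC[C@@H]4CO[C@@](Cn5cncn5)(c5ccc(Cl)cc5Cl)O4)cc3)CC2)cc1` carries a 4-phenylbutyl group on that carbonyl carbon, and in this assay compound 1 gives > 50000 nM, again a limit. Compound 2 `O=C(CCc1ccccc1)Nc1ccc(N2CCN(c3ccc(OC[C@@H]4CO[C@@](Cn5cncn5)(c5ccc(Cl)cc5Cl)O4)cc3)CC2)cc1` carries a phenethyl group there, and in this assay compound 2 gives > 50000 nM, also a limit. The steps among them, a step that the two limits leave unreadable from compound 1 to compound 2, a step that the two limits leave unreadable from compound 1 to compound 3 and a step that the two limits leave unreadable from compound 2 to compound 3, cannot be given a size, because of the limit of > 50000 nM in this assay, at which 3 of the 3 values shown sit.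

Compound 4 `O=C(Nc1ccc(N2CCN(c3ccc(OC[C@@H]4CO[C@@](Cn5cncn5)(c5ccc(Cl)cc5Cl)O4)cc3)CC2)cc1)c1cccs1` has not yet been measured; it differs from compound 3 by thiophen-2-yl in place of 3,4-difluorophenyl on a carbonyl carbon. Among the measured compounds shown here, none of the measured steps has a readable size, so there is no basis to expect compound 4 to move away from compound 3 beyond the scatter. Compound 4 is therefore expected to sit at the limit as well, estimated at 60000 nM with a range from 30000 nM to 120000 nM, meaning an expected step that the limit leaves unreadable from compound 3 to compound 4.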

Compound 4, half-maximal inhibitory concentration: > 50000 nM
Compound 4: only a limit was reported; the forecaster's own chance of this, stated with the estimate: 85%; the middle value lies beyond the limit too.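

Among the compounds shown here, no step from compound 4 to compound 1, compound 2 or compound 3 can be read, because all four share a single limit and not a number: the limit of > 50000 nM in this assay, at which 4 of the 4 values shown sit. The compounds shown leave open how far each lies past that limit, and whether any group on the carbonyl carbon would give a readable value in this assay.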